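The compounds below may be only part of what the source reports. "The series", "measured", "known", "first", "only" and "open" are said of these compounds alone.

Measured so far:
- compound 1 `COc1ccc(-c2ccc3c(NCCCNCc4cccc(OC)c4O)ccnc3c2)cc1`, 32000 nM
- compound 2 `COc1ccc(-c2ccc3c(NCCCNCc4ccco4)ccnc3c2)cc1`, 32000 nM
- compound 3 `COc1ccc(-c2ccc3c(NCCCNCc4cc(F)ccc4OC)ccnc3c2)cc1`, 32000 nM

In a physicochemical assay for solubility, with a stated time of 18 h, at pH 7.4 (a higher number here means a more soluble compound, a lower number a less soluble compound), compound 3 stands level with compound 1 and compound 2. The three measured steps all change the aryl group on a saturated chain carbon bound to an amine nitrogen: no change at the digits printed from compound 1 to compound 2 (within the scatter), no change at the digits printed from compound 1 to compound 3 (within the scatter) and no change at the digits printed from compound 2 to compound 3 (within the scatter). None of them shifts the read-out beyond the scatter.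

Compound 4 `COc1ccc(F)cc1CNCCCNc1ccnc2cc(-c3cccc4ccccc34)ccc12` differs from compound 3 elsewhere: naphthalen-1-yl in place of 4-methoxyphenyl on an aromatic carbon. Among the compounds with values here, this change sits on the shared core rather than on the chain end, so none of the measured steps bears on it directly; they show only that the chain-end aryl group left the read-out unchanged. There is therefore no measured guide for the size or direction of the step, and the estimate must be wide. Compound 4 is expected to give 12000 nM, with a range from 2000 nM to 32000 nM. The estimate means a step of a 2.7-fold lower number from compound 3 to compound 4 (0.43 log units; beyond the scatter), which is put forward as an expectation rather than a result drawn from a measured pair.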

Compound 4, solubility: 32000 nM
Estimate against measurement, compound 4: 2.7-fold (0.43 log units) below; the range from low to high includes it.
By their numbers in this assay, from the lowest: compounds 1, 2, 3 and 4 (each within the scatter of the next).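

In this assay, within the data shown here, the earlier steps changed only the aryl group at the chain end, whereas this one is the first to change a group on the shared core, and naphthalen-1-yl in place of 4-methoxyphenyl gives no change at the digits printed from compound 3 to compound 4 (within the scatter) in this read-out. On this aromatic carbon, then, a group with two six-membered aromatic rings of carbon only and no hydrogen-bond acceptor reads level with a group that has one such ring and one hydrogen-bond acceptor, so the value holds across changes at the chain end and on the core in these four compounds. Nothing measured here explains why the value stays the same.

Going by these compounds, it remains open whether a different kind of group on this aromatic carbon, such as a carboxylic acid or a morpholine ring, would move the value beyond the scatter. The compounds shown also leave open what a change to the chain itself would do, such as a longer chain joining the two amine nitrogens.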